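Cytotoxicity on Vero cells across a shared benzimidazole-free core series

This account rests on a few compounds, and the source may have more. Where it says the series, first, only, none or still open, it means among the compounds named here.

Measured compounds:
compound 1, `CCN(CC)c1cc2[nH]c(C3CCCCC3)nc2cc1NC(=O)c1ccc(N(C)C)cc1`: "not determined" (no result reported)
compound 2, `CCCN(CCC)c1cc2[nH]c(C3CCCCC3)nc2cc1NC(=O)OCc1ccccc1`: > 100 ug/mL
compound 3, `CCCCCC(=O)Nc1cc2nc(C3CCCCC3)[nH]c2cc1N(C)C`: > 100 ug/mL

Compound 1, `CCN(CC)c1cc2[nH]c(C3CCCCC3)nc2cc1NC(=O)c1ccc(N(C)C)cc1`, is the starting point of this step. In an ADME assay on Vero cells (Chlorocebus sabaeus) for cytotoxicity, read by resazurin assay, with a stated time of 3 days (on this read-out higher numbers stand for weaker inhibition and lower numbers for stronger inhibition), compound 1 gives "not determined" (no result reported), so no number stands for it, and its place can only be judged from its two neighbours on the shared core. Compound 2, `CCCN(CCC)c1cc2[nH]c(C3CCCCC3)nc2cc1NC(=O)OCc1ccccc1`, reaches only a limit of this assay, > 100 ug/mL, not a number. Compound 3, `CCCCCC(=O)Nc1cc2nc(C3CCCCC3)[nH]c2cc1N(C)C`, likewise reaches only a limit, > 100 ug/mL. The picture is summed up by the limit of > 100 ug/mL in this assay, at which 2 of the 3 values shown sit.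

Compound 4, `CCN(CC)c1cc2[nH]c(C3CCCCC3)nc2cc1NC(=O)c1cccc(Br)c1`, differs from compound 1 in one place: 3-bromophenyl in place of 4-(dimethylamino)phenyl on a carbonyl carbon. Among the measured compounds shown here, no measured step on this core shows what such a change does in this assay, so no direction is backed by data; the two compounds that were measured both sit at the limit, and a step beyond the usual scatter is not expected from them alone. Compound 4 is therefore expected to give 80 ug/mL, within a range from 25 ug/mL to 200 ug/mL, with a fair chance that only a limit is reported.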

Compound 4, half-maximal inhibitory concentration: > 100 ug/mL
Compound 4: no number, only a limit; the forecaster's own chance of this, stated with the estimate: 55%; middle value at least 1.2-fold (0.09 log units) away from the limit.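

In this assay compound 4 gives > 100 ug/mL, which is a limit and not a number. Among the compounds shown here, compound 1 has no number either, so no step from compound 1 to compound 4 can be read. The compounds shown leave open what concentration of any of them would harm these cells.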